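Dichlorophenyl to Dimethoxyphenyl Exchange on an Aryl Amine

The source may hold more compounds than are shown below. What is called first, only, known or untested is meant among the compounds shown, and "the series" means these compounds.

Compound 1, `Nc1cc(N)c2nc(-c3ccccc3)c(Oc3ccc(Cl)c(Cl)c3)nc2c1`: < 100000 nM
Compound 2, `Nc1cc(N)c2nc(-c3ccccc3)c(NCc3ccc(Cl)c(Cl)c3)nc2c1`: < 100000 nM

In a functional assay on MOLT-4 cells (Homo sapiens) for inhibition, read by sulforhodamine B assay, with a stated time of 48 h (on this read-out lower numbers stand for stronger inhibition of growth and higher numbers for weaker inhibition of growth), compound 1 gives < 100000 nM, which is a limit of the assay rather than a number. Compound 2 likewise gives < 100000 nM in this assay, again a limit. Compound 2 therefore stands at the limit of < 100000 nM in this assay, at which 2 of the 2 values shown sit, with no number of its own to compare. Compound 3, `COc1ccc(CNc2nc3cc(N)cc(N)c3nc2-c2ccccc2)cc1OC`, differs from compound 2 by 3,4-dimethoxyphenyl in place of 3,4-dichlorophenyl on a saturated chain carbon bound to a nitrogen on an aromatic ring. Among the measured compounds shown here, no measured pair shows this change. The step that the limit leaves unreadable from compound 2 to compound 3 is expected to remain within the scatter. Compound 3 is estimated at 30000 nM, within 5000 nM to 100000 nM, and is likely to be reported again as a limit.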

Compound 3, concentration for total growth inhibition: < 100000 nM
Compound 3 was reported as a limit; the forecaster's own chance of this, stated with the estimate: 70%; the middle value lies beyond the limit too.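

Among the compounds shown here, compound 2 and compound 3 are each reported only as a limit, and no step between them can be read. On these data alone, the size of the exchange of 3,4-dichlorophenyl for 3,4-dimethoxyphenyl in this assay stays open.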